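Chloro to fluoro on the benzyl ring of compound 3

The compounds below may be only part of what the source reports. "The series", "measured", "known", "first", "only" and "open" are said of these compounds alone.

Measured compounds:
compound 1 `CC(C(=O)NCc1ccccc1Cl)N1C(=O)CCC1=O`: "not determined" (no result reported)
compound 2 `CC(C(=O)NCc1cccc(F)c1)N1C(=O)CCC1=O`: "not determined" (no result reported)
compound 3 `CCC(C(=O)NCc1ccccc1Cl)N1C(=O)CCC1=O`: 76.4 mg/kg

The set contains three measured entries, yet only compound 3 `CCC(C(=O)NCc1ccccc1Cl)N1C(=O)CCC1=O` carries a number. Compound 1 `CC(C(=O)NCc1ccccc1Cl)N1C(=O)CCC1=O` was entered in a functional assay on the whole organism (strain Albino Swiss CD1) with Mus musculus as the target (on this read-out lower numbers stand for an effect already at smaller amounts and higher numbers for an effect only at larger amounts of compound), with the outcome "not determined" (no result reported), and compound 2 `CC(C(=O)NCc1cccc(F)c1)N1C(=O)CCC1=O` likewise stands in this assay with "not determined" (no result reported), so nothing can be said about how they compare with compound 3. In this assay compound 3 gives 76.4 mg/kg, which is therefore the only anchor for any expectation.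

Compound 4 `CCC(C(=O)NCc1ccccc1F)N1C(=O)CCC1=O` is not yet measured. It differs from compound 3 by fluoro in place of chloro on an aromatic carbon. No comparison between two measured compounds is available, so the size of such a step here cannot be read from data; it can only be judged as uncertain, with a halogen exchange of this kind expected to move the dose by no more than a modest amount, in either direction, and quite possibly not beyond the scatter.

Compound 4 is therefore estimated at 100 mg/kg, with a range from 45 mg/kg to 220 mg/kg. That estimate means an expected step of a 1.3-fold higher number from compound 3 to compound 4 (0.12 log units; within the scatter), leaning slightly toward a larger dose.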

Compound 4, dose for half-maximal effect: 65.7 mg/kg
Compound 4: middle estimate off by 1.5-fold (0.18 log units), on the high side; low and high end bracket the measured number.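

In this assay, among these compounds, the first readable step at this place, on an aromatic carbon ortho to a large group, puts fluoro in place of chloro and gives a 1.2-fold lower number from compound 3 to compound 4 (0.07 log units; within the scatter). This shows that, for this pair, the exchange of one halogen for the other does not separate the two compounds, so the benzyl ring tolerates either chloro or fluoro here without a change that can be told from the scatter. No measurement is at hand that would bear on why this is so.

Steps involving compound 1 and compound 2 cannot be read, so the effect of the position of the halogen and of the chain on the shared core stays open. As far as these compounds go, whether a methoxy or trifluoromethyl group at this place, or a longer chain on the core, would move the dose beyond the scatter also remains unknown.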